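Swapping pyridin-3-yl for 4-methoxyphenyl on compound 2

This account rests on a few compounds, and the source may have more. Where it says the series, first, only, none or still open, it means among the compounds named here.

Of the compounds shown here, three have numbers so far in a functional assay for inhibition, with Homo sapiens as the target (a higher number here means a weaker inhibitor, a lower number a stronger inhibitor), and a lower number marks a stronger inhibitor. Compound 2 (`O=C1CCc2cc(-c3csc(-c4cccnc4)n3)ccc2N1`) has a half-maximal inhibitory concentration of 1000 nM here, the lowest of the three numbers. Compound 1 (`Nc1ccc(-c2csc(-c3cccnc3)n2)cc1`) gives 3000 nM and compound 3 (`COc1ccc(Cc2nc(-c3ccc4c(c3)CCC(=O)N4)cs2)cc1OC`) gives 10000 nM in the same read-out, and both numbers lie beyond the usual scatter from that of compound 2.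

Compound 4 (`COc1ccc(-c2nc(-c3ccc4c(c3)CCC(=O)N4)cs2)cc1`) has not been measured yet. It keeps the core of compound 2 and differs in one place. The change is 4-methoxyphenyl in place of pyridin-3-yl on an aromatic carbon and it sits on an aromatic carbon of a five-membered aromatic ring with 1 nitrogen and 1 sulfur.

Among the measured compounds shown here, no measured pair shows this change on its own, so the expectation rests on thin evidence. For the measured compounds named here, compound 3 shares the core of compound 2 and has no pyridin-3-yl, and in this assay compound 3 gives 10000 nM as the highest number so far. A shift toward a higher number, meaning a weaker inhibitor, therefore seems more likely than a lower one. The estimated change is a 3.0-fold higher number from compound 2 to compound 4 (0.48 log units; beyond the scatter) as a moderate step. For compound 4 the expected value is 3000 nM with an estimated range from 800 nM to 10000 nM as the likely span.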

Compound 4, half-maximal inhibitory concentration: 9000 nM
Beside the measured number, compound 4's estimate is 3.0-fold (0.48 log units) below it; the range from low to high includes it.
By their numbers in this assay, from the lowest: compound 2; then compound 1; then compounds 4 and 3 (each within the scatter of the next).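

In this assay, among the compounds shown here, replacing pyridin-3-yl with 4-methoxyphenyl on an aromatic carbon of the five-membered ring gives a 9.0-fold higher number from compound 2 to compound 4 (0.95 log units; beyond the scatter), the first direct reading of a single change at this position. Compound 3 had offered only an indirect hint, as a compound with the same core but a different group; here everything else in the molecule stays the same, so the rise in the number belongs to this one swap. For the compounds shown here, this position therefore clearly matters in this assay, and pyridin-3-yl is the better of the two groups compared directly, although nothing measured so far bears on why the number rises.

The swap changes two things at once: the ring nitrogen of pyridin-3-yl leaves and a methoxy group enters, so the compounds shown cannot say which of the two accounts for the step. A plain phenyl ring at this position would separate those two changes, while pyridin-4-yl would show whether the location of the ring nitrogen matters as well.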